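A few compounds are considered here, and "the series" means these few. Any claim that something is new, unique, unknown or untested is made for them only; others in the source may bear on it.

Of the compounds shown here, three built on a shared core have been measured in a functional assay on L1210 cells (Mus musculus) for inhibition, read by cell counting, with a stated time of 2 days; a higher number here means a weaker inhibitor, a lower number a stronger inhibitor. Compound 1 `C=C(Br)C(=O)Nc1cccc(-c2cn3nc(Cc4ccccc4)sc3n2)c1` gives 3000 nM. Compound 2 `Nc1cccc(-c2cn3nc(Cc4ccccc4)sc3n2)c1` differs from compound 1 in a single place: hydrogen in place of (1-bromoethenyl)carbonyl on a nitrogen on an aromatic ring. In this assay compound 2 gives 7400 nM, which amounts to a 2.5-fold higher number from compound 1 to compound 2 (0.39 log units; beyond the scatter). Compound 3 `C=C(Br)C(=O)Nc1cccc(-c2cn3nc(-c4cccc(OC)c4)sc3n2)c1` differs from compound 1 elsewhere on the core: 3-methoxyphenyl in place of benzyl on an aromatic carbon. In this assay compound 3 gives 580 nM, and the step from compound 1 to compound 3 is a 5.2-fold lower number from compound 1 to compound 3 (0.71 log units; beyond the scatter). Compound 3 therefore carries the lowest number of the three, with both other compounds lying beyond the scatter from it.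

Compound 4 `COc1cccc(-c2nn3cc(-c4cccc(N)c4)nc3s2)c1` has not yet been measured. It stands to compound 3 as compound 2 stands to compound 1: hydrogen in place of (1-bromoethenyl)carbonyl on a nitrogen on an aromatic ring. The surroundings of the changed place are described in the same words for both pairs, so this is the same change made on a different core, the two cores differing as set out above for compound 1 and compound 3. Within the data shown here, the only guide to its size is the step from compound 1 to compound 2, so the step from compound 3 to compound 4 in this assay is expected to be about a 2.6-fold higher number from compound 3 to compound 4 (0.41 log units; beyond the scatter), a modest loss because a 2.5-fold higher number from compound 1 to compound 2 (0.39 log units; beyond the scatter) was modest. Compound 4 is therefore estimated to give about 1500 nM, most likely between 700 nM and 3500 nM.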

Compound 4, half-maximal inhibitory concentration: > 250000 nM
Compound 4: no number, only a limit; the forecaster's own chance of this, stated with the estimate: 3%; at least 160-fold (2.22 log units) between middle value and limit.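

In this assay, compound 4 gives > 250000 nM, which is a limit of the assay and not a number. Putting hydrogen in place of (1-bromoethenyl)carbonyl on the core of compound 3 gives an at least 430-fold higher number from compound 3 to compound 4 (2.63 log units; beyond the scatter), so in these two pairs the change does not carry over from one core to the other at a constant size: the same change on two cores in this assay, a 2.5-fold higher number (0.39 log units; beyond the scatter) from compound 1 to compound 2 and an at least 430-fold higher number (2.63 log units; beyond the scatter) from compound 3 to compound 4, at least 170-fold (2.24 log units) apart, beyond the scatter of two such steps This shows that the size of the step depends on the core in these two pairs, but it does not show why the cores differ, and one pair on each core gives no rule for other cores in the series.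

The compounds shown leave open whether the large step on the core of compound 3 belongs to the whole (1-bromoethenyl)carbonyl group or to only part of it, a question that a plain acetyl or a bromine-free acryloyl on the same nitrogen would address. They also leave open how the step behaves when a plain phenyl or a longer alkyl chain stands in place of the benzyl of compound 1 or the 3-methoxyphenyl of compound 3.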